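The source may report more compounds than this note shows. Statements on the series, on what has been measured and on what is new or still open speak of the compounds shown alone.

Measured so far:
- compound 1 `CCC(CC)n1c(-c2ccc(OCc3c(-c4c(Cl)cccc4Cl)noc3C(C)C)cc2F)nc2ccc(C(=O)O)cc21`: 69.3 nM
- compound 2 `CC(C)c1onc(-c2c(Cl)cccc2Cl)c1COc1ccc(-c2nc3ccc(C(=O)O)cc3n2Cc2ccc(F)cc2)cc1`: 105 nM
- compound 3 `CCn1c(-c2ccc(OCc3c(-c4c(Cl)cccc4Cl)noc3C(C)C)cc2)nc2ccc(C(=O)O)cc21`: 19.3 nM

All three share one core and were tested in an assay on isolated protein for agonist activity at Bile acid receptor (Homo sapiens), read by TR-FRET; on this read-out higher numbers stand for an effect only at larger amounts of compound and lower numbers for an effect already at smaller amounts. Compound 2 stands at the top of these numbers with 105 nM. Compound 1 at 69.3 nM lies within the usual scatter of compound 2, so the two cannot be told apart. Compound 3, at 19.3 nM, is clearly lower than compound 2.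

The new compound is compound 4 `CCCn1c(-c2ccc(OCc3c(-c4c(Cl)cccc4Cl)noc3C(C)C)cc2)nc2ccc(C(=O)O)cc21`. Set against compound 2, the change is ethyl in place of 4-fluorophenyl on a saturated chain carbon bound to an aromatic nitrogen.

Among the compounds with values here, one measured step bears on this directly: a 5.4-fold lower number from compound 2 to compound 3 (0.74 log units; beyond the scatter), where the same 4-fluorophenyl group was replaced by a methyl at the same position. The change to compound 4 is of the same kind, only with a chain one carbon longer entering. Compound 1 and compound 3 differ in two places at once, so their values alone say nothing separate about the chain length.

On this basis compound 4 is expected to follow the direction seen in that step, with a lower number than compound 2 that lies beyond the scatter, roughly a 4.2-fold lower number from compound 2 to compound 4 (0.62 log units; beyond the scatter). Compound 4 is therefore estimated at 25 nM, with a likely range from 10 nM to 60 nM.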

Compound 4, half-maximal effective concentration: 96.4 nM
For compound 4 the middle estimate is 3.9-fold (0.59 log units) below the measured one; the whole stated range lies below it.
By their numbers in this assay, from the lowest: compound 3; then compounds 1, 4 and 2 (each within the scatter of the next).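

In this assay, taking away the 4-fluorobenzyl group and putting propyl in its place makes no clear difference (a 1.1-fold lower number from compound 2 to compound 4 (0.04 log units; within the scatter)), so losing the aromatic ring at this position does not by itself bring the number down, as compound 3 alone might have suggested. The sharper finding is how sensitive this position is to a very small change: a methyl in place of hydrogen on a saturated chain carbon, two bonds along the chain from an aromatic nitrogen, takes the number clearly up (a 5.0-fold higher number from compound 3 to compound 4 (0.70 log units; beyond the scatter)), leaving compound 4 level with compound 2 and showing that the low number of compound 3 does not extend to every small chain here. Nothing in the available data explains why this single added methyl has so large an effect.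

From the compounds shown here alone, it remains open whether a longer chain such as butyl would take the number higher still or make no further difference. Equally open, going by these compounds, is how a chain of similar length ending in an amine or a hydroxyl group would behave at this position.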